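Benzimidazole replacement on the shared core: microsomal clearance notes

The source may hold more compounds than are shown below. What is called first, only, known or untested is meant among the compounds shown, and "the series" means these compounds.

Measured set:
- compound 1 `Cc1cc(C)c(-c2nc3ccccc3[nH]2)cc1NC(=O)c1ccc(OCc2ccccn2)cc1` gives 21 mL.min-1.g-1
- compound 2 `Cc1cc(C)c(-c2c[nH]nc2C)cc1NC(=O)c1ccc(OCc2ccccn2)cc1` gives 55 mL.min-1.g-1
- compound 3 `Cc1cc(C)c(-c2ccccn2)cc1NC(=O)c1ccc(OCc2ccccn2)cc1` gives 296 mL.min-1.g-1

All three are read in an ADME assay on microsomes from liver (Rattus norvegicus) for metabolic stability; on this read-out lower numbers stand for slow clearance and higher numbers for fast clearance. Compound 1 has the lowest number of the three; its nearest neighbour is compound 2, and the farthest is compound 3. The two steps away from compound 1 both raise the number: a 2.6-fold higher number from compound 1 to compound 2 (0.42 log units; beyond the scatter) and a 14-fold higher number from compound 1 to compound 3 (1.15 log units; beyond the scatter); between the other two there is a 5.4-fold higher number from compound 2 to compound 3 (0.73 log units; beyond the scatter).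

Compound 4 `Cc1cc(C)c(-c2ccc(N)cn2)cc1NC(=O)c1ccc(OCc2ccccn2)cc1` is not yet measured in this assay. It differs from compound 1 by 5-aminopyridin-2-yl in place of 1H-benzimidazol-2-yl on an aromatic carbon. For the measured compounds named here, the step that bears most directly on it is the one to compound 3, where pyridin-2-yl replaced the same group at the same position and gave a large rise, a 14-fold higher number from compound 1 to compound 3 (1.15 log units; beyond the scatter). Compound 4 carries a pyridin-2-yl as well, with an amino group added, so a rise beyond the scatter is expected in this assay; how far the added amino group moves the number away from compound 3 cannot be read from the three measured compounds, so the range is kept wide. The expected step is a 7.1-fold higher number from compound 1 to compound 4 (0.85 log units; beyond the scatter). For compound 4 the estimate is 150 mL.min-1.g-1, with a range from 50 mL.min-1.g-1 to 400 mL.min-1.g-1.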

Compound 4, intrinsic clearance in microsomes: 32 mL.min-1.g-1
The estimate for compound 4 lay 4.7-fold (0.67 log units) above the measured number, outside the stated range (below it).
By their numbers in this assay, from the lowest: compounds 1, 4 and 2 (each within the scatter of the next, the first and the last beyond it); then compound 3.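

In this assay, for the compounds shown here, replacing hydrogen with amino on the pyridin-2-yl ring produces a shift on the same scale as the ring replacements seen so far (a 9.3-fold lower number from compound 3 to compound 4 (0.97 log units; beyond the scatter)), and it is the first step in the set that changes only a substituent on that ring. With this substituent, 5-aminopyridin-2-yl stands within the scatter of 1H-benzimidazol-2-yl (a 1.5-fold higher number from compound 1 to compound 4 (0.18 log units; within the scatter)) and of 3-methyl-1H-pyrazol-4-yl (a 1.7-fold lower number from compound 2 to compound 4 (0.24 log units; within the scatter)), so a low number at this position does not depend on the fused bicyclic group, and a single six-membered aromatic ring can reach the same level. No data at hand explain why the amino group has this effect.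

As far as these compounds go, it remains open whether this shift is specific to an amino group, or whether a hydroxyl, a methoxy or an acetylamino group on the same carbon of the pyridine ring would give a similar number. From the compounds shown here alone, it is also open whether a methylamino or dimethylamino group would keep the number in the range of compound 4.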